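Ring Exchange on a Sulfonamide Phenyl: Compound 3 to Compound 4

The source may report more compounds than this note shows. Statements on the series, on what has been measured and on what is new or still open speak of the compounds shown alone.

Measured compounds:
Compound 1 `CS(=O)(=O)Nc1ccc(Cl)c2c1CCCC2c1c[nH]cn1`: 2880 nM
Compound 2 `CS(=O)(=O)Nc1cccc2c1CCCCC2c1c[nH]cn1`: 2510 nM
Compound 3 `CCS(=O)(=O)Nc1cccc(-c2c[nH]cn2)c1`: < 10000 nM

Of the compounds shown here, three have been tested in an assay on isolated protein for binding affinity to Alpha-1D adrenergic receptor (Rattus norvegicus), read by radioligand binding; on this read-out higher numbers stand for weaker inhibition and lower numbers for stronger inhibition. Compound 1 gives 2880 nM and compound 2 gives 2510 nM; these two values lie within the scatter of each other, so no order between them can be read. Compound 3 is known only by a limit of this assay, < 10000 nM, and not by a number, as noted in the limit of < 10000 nM in this assay, at which 1 of the 3 values shown sits. Where compound 3 stands among the three can therefore not be said more closely than that.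

Compound 4 `CCS(=O)(=O)Nc1cccc(NC2=NCCN2)c1` has not been measured. It differs from compound 3 in one place: a group of 6 heavy atoms (3 carbon, 3 nitrogen; one five-membered non-aromatic ring with 2 hetero atoms) in place of a group of 5 heavy atoms (3 carbon, 2 nitrogen; one five-membered aromatic ring with 2 hetero atoms), on an aromatic carbon. Going by the values given here, no step between two measured compounds involves this exchange, so the direction of this change in this assay cannot be read from the data. Because compound 3 gives only the limit < 10000 nM, any estimate for compound 4 rests on little.

Compound 4 is therefore expected to give around 2000 nM, with a plausible range from 200 nM to 10000 nM. This estimate means a step that the limit leaves unreadable from compound 3 to compound 4, which is expected to be small or none beyond the scatter.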

Compound 4, inhibition constant: 355 nM
Compound 4: middle estimate off by 5.6-fold (0.75 log units), on the high side; low and high end bracket the measured number.
By their numbers in this assay, from the lowest: compound 4; then compounds 2 and 1 (each within the scatter of the next).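

No step from compound 3 to compound 4 can be read in this assay, since compound 3 is known only by a limit and not by a number: the limit of < 10000 nM in this assay, at which 1 of the 4 values shown sits.

The compounds shown leave open how large the effect in this assay is of exchanging the 1H-imidazol-4-yl group for the five-membered non-aromatic ring group, and in which direction it runs.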